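This account rests on a few compounds, and the source may have more. Where it says the series, first, only, none or still open, it means among the compounds named here.

Measured compounds:
compound 1 `Cc1nc(C)c([C@H](OC(C)(C)C)C(=O)O)c(N2CCC(C)(C)CC2)c1-c1ccc(OCCc2ccc(F)cc2F)cc1`, tested in a toxicity assay on MT2 cells (Homo sapiens) for cytotoxicity, read by XTT assay, with a stated time of 4 days (on this read-out lower numbers stand for higher toxicity in this test and higher numbers for lower toxicity in this test), gives >= 33500 nM.
compound 2 `Cc1nc(C)c([C@H](OC(C)(C)C)C(=O)O)c(N2CCC(C)(C)CC2)c1-c1ccc(OC2CCCC2c2ccc(F)cc2)cc1`, tested in this assay, gives >= 32000 nM; >= 32000 nM (2 entries).

Compound 2 gives only a limit in this assay. For compound 1 the result in this assay is likewise a limit of the assay and not a number: the cells tolerated compound 1 up to the highest concentration tested, so it stands at the limit of >= 33500 nM in this assay, at which 1 of the 2 values shown sits. Among the compounds with values here, because both results are limits, no step between the two measured compounds can be sized, and neither compound can be placed above or below the other.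

Compound 3 `Cc1nc(C)c([C@H](OC(C)(C)C)C(=O)O)c(N2CCC(C)(C)CC2)c1-c1ccc(OCCc2cccnc2)cc1` has not been measured. It differs from compound 1 by pyridin-3-yl in place of 2,4-difluorophenyl on a saturated chain carbon, two bonds along the chain from an oxygen on an aromatic ring. Within the data shown here, with no measured step to lean on, the step from compound 1 to compound 3 in this assay is expected to be none beyond the scatter, as a number no higher from compound 1 to compound 3 (the limit leaves the size open) expresses. Compound 3 is therefore expected to give about 33500 nM, with a range from 12000 nM to 70000 nM. A result for compound 3 that is again only a limit of the assay is considered likely.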

Compound 3, half-maximal cytotoxic concentration: >= 25000 nM
Compound 3: no number, only a limit (the forecaster's own chance of this, stated with the estimate: 80%); the middle value does not contradict the limit.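

In this assay, compound 1 and compound 3 both give limits of the assay and not numbers. The step between these two compounds cannot be read. The compounds shown leave open the concentration, if any, at which each would become toxic to these cells.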